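The source may report more compounds than this note shows. Statements on the series, on what has been measured and on what is new or still open speak of the compounds shown alone.

Values in a functional assay on Vero cells (Chlorocebus sabaeus) for cytotoxicity; a lower number here means that less compound is tolerated, a higher number that more compound is tolerated:
Compound 1 `O=c1[nH]c(=O)n([C@H]2CO[C@@H](CO)S2)cc1/C=C/Br`: 100 ug/mL
Compound 2 `O=c1[nH]c(=O)n([C@@H]2CO[C@@H](CO)S2)cc1/C=C/Br`: 30 ug/mL
Compound 3 `O=c1[nH]c(=O)n([C@@H]2CO[C@H](CO)S2)cc1/C=C/Br`: > 100 ug/mL (a limit)

Compound 3 holds only the limit > 100 ug/mL in this assay and no number.

Compound 4 `O=c1[nH]c(=O)n([C@H]2CO[C@H](CO)S2)cc1/C=C/Br` follows from compound 3 through the two compounds have the same atoms and bonds and differ only in configuration as drawn: 1 of 3 stereo elements differ; a stereocentre at a saturated ring carbon is drawn S in compound 3 and R in compound 4 with nothing leaving and nothing entering. The closest measured step is a 3.3-fold lower number from compound 1 to compound 2 (0.52 log units; beyond the scatter), where a stereocentre at a saturated ring carbon is drawn R in compound 1 and S in compound 2. The same centre changes on the way to compound 4, but from S to R, so it runs in the sense of going back from compound 2 to compound 1. That sense raised the number. The other centre also moves the number, as an at least 3.3-fold higher number from compound 2 to compound 3 (0.52 log units; beyond the scatter) shows. With both centres changed, a number no lower from compound 1 to compound 3 (the limit leaves the size open) has no readable size, and the limit of > 100 ug/mL in this assay, at which 1 of the 3 values shown sits, leaves the starting point open.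

Within the data shown here, the one comparable step thus points to a number no lower, yet compound 3 offers no number to start from. No step beyond the scatter is therefore expected in this assay, and a second reading at the limit is quite possible. The step expected here is a number no higher from compound 3 to compound 4 (the limit leaves the size open) as an estimate. The estimate for compound 4 is 100 ug/mL, with an expected range from 40 ug/mL to 200 ug/mL as its span.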

Compound 4, half-maximal cytotoxic concentration: 100 ug/mL
Compound 4: middle estimate and measured number agree at the digits printed; the measured number falls inside the stated range.
By their numbers in this assay, from the lowest: compound 2; then compounds 1 and 4 (each within the scatter of the next).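

In this assay the set now shows no change at the digits printed from compound 1 to compound 4 (within the scatter), where a stereocentre at a saturated ring carbon is drawn R in compound 1 and S in compound 4 while the other stereocentre stays as drawn. The same R to S change, made with the other stereocentre as drawn in compound 2, gives an at least 3.3-fold higher number from compound 2 to compound 3 (0.52 log units; beyond the scatter), so what this centre does in this assay depends on the configuration of its partner. The result also gives a 3.3-fold higher number from compound 2 to compound 4 (0.52 log units; beyond the scatter), and with this step compound 2 stands apart from each of the other three stereoisomers, all of which tolerate more compound.

Compound 3 holds only a limit, > 100 ug/mL. From the compounds shown here alone, the set shows a number no higher from compound 3 to compound 4 (the limit leaves the size open), so how far the two lie apart stays unknown. Going by these compounds, all four compounds share the same atoms and bonds, so it remains open whether this dependence between the two centres would persist if a carboxylic acid or an amine took the place of the hydroxymethyl group, or if a longer chain replaced the bromovinyl group.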